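Acetylation of the free hydroxy in a weakly cytotoxic pair

This account rests on a few compounds, and the source may have more. Where it says the series, first, only, none or still open, it means among the compounds named here.

Two esters on the shared core have been measured. Compound 1 `COc1ccc(C(=O)O[C@H]2CC(C)=C[C@H](O)[C@@]3(C)[C@@H](OC(C)=O)C[C@@](O)(C(C)C)[C@H]23)cc1` in a functional assay on SEM cells (Homo sapiens) for cytotoxicity, read by MTT assay, with a stated time of 72 h (a lower number here means a stronger inhibitor, a higher number a weaker inhibitor), gives 18100 nM. Compound 2 `COc1ccc(C(=O)O[C@H]2CC(C)=C[C@H](OC(C)=O)[C@]3(C)[C@@H]2[C@](O)(C(C)C)C[C@@H]3O)cc1` in this assay gives 26500 nM, the highest of the two numbers, though the nearest, compound 1, sits within the scatter of it, so the pair cannot be told apart. For the measured compounds named here, no step between measured compounds that differ in one place is available.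

Compound 3 `COc1ccc(C(=O)O[C@H]2CC(C)=C[C@H](OC(C)=O)[C@@]3(C)[C@@H](OC(C)=O)C[C@@](O)(C(C)C)[C@H]23)cc1` differs from compound 2 by acetyl in place of hydrogen on an oxygen on a saturated carbon. Cut one bond further out, the change reads hydroxy to acetoxy. Going by the values given here, nothing among the measured compounds isolates this change, so the expected step in this assay is a 1.2-fold lower number from compound 2 to compound 3 (0.08 log units; within the scatter), small and not beyond the scatter in either direction. Compound 3 in this assay is estimated at 22000 nM, within a range from 8000 nM to 60000 nM.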

Compound 3, half-maximal inhibitory concentration: 15000 nM
The estimate for compound 3 lay 1.5-fold (0.17 log units) above the measured number; the range from low to high includes it.
By their numbers in this assay, from the lowest: compounds 3, 1 and 2 (each within the scatter of the next).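

Acetyl in place of hydrogen on an oxygen on a saturated carbon can now be read twice on the shared core in this assay, once at each of the two oxygens that differ between compound 1 and compound 2 (first a 1.8-fold lower number from compound 2 to compound 3 (0.25 log units; within the scatter), then a 1.2-fold lower number from compound 1 to compound 3 (0.08 log units; within the scatter)). Both steps lie within the scatter, so hydroxy to acetoxy shows no measurable effect at either oxygen, and compound 3, with both acetoxy groups, cannot be told apart from either parent. Nothing measured alongside these values offers an explanation for this.

From the compounds shown here alone, whether a longer acyl chain or an amine-bearing acyl group at these oxygens would give a step beyond the scatter remains open. So does the effect of replacing the 4-methoxybenzoate ester with a carboxylic acid.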